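Bromo to cyano swap carried into the alcohol series

The compounds below may be only part of what the source reports. "The series", "measured", "known", "first", "only" and "open" are said of these compounds alone.

Compound 1 `Cc1ccccc1/C(=C\c1cc(OCc2ccsc2)ccc1Br)C(=O)O` and compound 3 `OC/C(=C/c1cc(OCc2ccsc2)ccc1Br)c1ccccc1` both carry a bromo group; how their two cores differ is not broken down here. In an assay on A10 cells for binding affinity to Endothelin-1 receptor (Rattus norvegicus) (a higher number here means a weaker inhibitor, a lower number a stronger inhibitor), compound 1 gives 3000 nM, and compound 3 gives 2100 nM, a gap that lies within the scatter. Compound 2 `Cc1ccccc1/C(=C\c1cc(OCc2ccsc2)ccc1C#N)C(=O)O` carries cyano in place of bromo on an aromatic carbon; in this assay compound 2 gives 300 nM, and the step is a 10-fold lower number from compound 1 to compound 2 (1.00 log units; beyond the scatter). Compound 4 `N#Cc1ccc(OCc2ccsc2)cc1/C=C(/CO)c1ccccc1` is not yet measured; it carries cyano in place of bromo on an aromatic carbon, the same change made on the core of compound 3, with the place described in the same words. Among the measured compounds shown here, for compound 4 a step of about the same size is expected, an 8.4-fold lower number from compound 3 to compound 4 (0.92 log units; beyond the scatter), because the one measured instance a 10-fold lower number from compound 1 to compound 2 (1.00 log units; beyond the scatter) fell beyond the scatter and the starting values of compound 1 and compound 3 lie within the scatter of each other. A single occurrence is a thin basis, so the range is kept wide. Compound 4 is estimated at 250 nM in this assay, expected to fall between 90 nM and 800 nM.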

Compound 4, half-maximal inhibitory concentration: 800 nM
Compound 4: the middle estimate sits 3.2-fold (0.51 log units) below what was measured, and the stated range covers the measured number.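

Carried onto the core of compound 3, cyano in place of bromo again gives a lower number in this assay (a 2.6-fold lower number from compound 3 to compound 4 (0.42 log units; beyond the scatter)), so the direction of the step is the same on both cores shown. The size of the step does not carry over unchanged, as the two steps set side by side show: the same change on two cores in this assay, a 10-fold lower number (1.00 log units; beyond the scatter) from compound 1 to compound 2 and a 2.6-fold lower number (0.42 log units; beyond the scatter) from compound 3 to compound 4, 3.8-fold (0.58 log units) apart, beyond the scatter of two such steps

With a single pair on each core, this shows that the size of the swap's step differed between these two cores, but it does not show which difference between the cores goes with the smaller step, nor how the step would behave on any further core.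

The compounds shown leave open whether other groups in place of bromo, such as an amine or a carboxylic acid, would give steps that also differ between the two cores. Also open, from the compounds shown here alone, is how either core would respond to a longer chain in place of the (thiophen-3-yl)methoxy group.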